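This account rests on a few compounds, and the source may have more. Where it says the series, first, only, none or still open, it means among the compounds named here.

The measured compounds are compound 1 `O=C(CN1CCN(C(=O)c2ccc(Br)cc2)CC1)N1CCN(CCCc2c[nH]c3ccc(F)cc23)CC1` with 60500 nM, compound 2 `Cc1ccc(C(=O)N2CCN(CC(=O)N3CCN(CCCc4c[nH]c5ccc(F)cc45)CC3)CC2)cc1` with 141000 nM, and compound 3 `COc1ccc2[nH]cc(CCCN3CCN(C(=O)CN4CCN(C(=O)c5ccc(Br)cc5)CC4)CC3)c2c1` with 80500 nM, all read in an ADME assay on HEK293 cells (Homo sapiens) for cytotoxicity, read by MTT assay, with a stated time of 72 h; a higher number here means a weaker inhibitor, a lower number a stronger inhibitor.

Compound 4 `COc1ccc2[nH]cc(CCCN3CCN(C(=O)CN4CCN(C(=O)c5ccc(C)cc5)CC4)CC3)c2c1` has not been measured. It differs from compound 3 by methyl in place of bromo on an aromatic carbon. The same change is seen once already: compound 2 differs from compound 1 by methyl in place of bromo on an aromatic carbon, and in this assay that gave a 2.3-fold higher number from compound 1 to compound 2 (0.37 log units; beyond the scatter). The two cores differ by methoxy in place of fluoro on an aromatic carbon, a change that gave a 1.3-fold higher number from compound 1 to compound 3 (0.12 log units; within the scatter). For compound 4 a step of similar size is expected, a 2.2-fold higher number from compound 3 to compound 4 (0.34 log units; beyond the scatter), because a 2.3-fold higher number from compound 1 to compound 2 (0.37 log units; beyond the scatter) lies beyond the scatter. This rests on a single earlier example, so the expectation is loose. Compound 4 is estimated at 175000 nM, expected to fall between 90000 nM and 340000 nM.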

Compound 4, half-maximal inhibitory concentration: 147000 nM
Beside the measured number, compound 4's estimate is 1.2-fold (0.08 log units) above it; the range from low to high includes it.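

In this assay, putting methyl in place of bromo on the core of compound 3 gives a 1.8-fold higher number from compound 3 to compound 4 (0.26 log units; within the scatter), and this agrees with the earlier step on the core of compound 1: the same change on two cores in this assay, a 2.3-fold higher number (0.37 log units; beyond the scatter) from compound 1 to compound 2 and a 1.8-fold higher number (0.26 log units; within the scatter) from compound 3 to compound 4, 1.3-fold (0.11 log units) apart, within the scatter of two such steps. Methoxy in place of fluoro, read on the methyl-bearing pair, gives a 1.0-fold higher number from compound 2 to compound 4 (0.02 log units; within the scatter), and it agrees in the same way: the same change on two cores in this assay, a 1.3-fold higher number (0.12 log units; within the scatter) from compound 1 to compound 3 and a 1.0-fold higher number (0.02 log units; within the scatter) from compound 2 to compound 4, 1.3-fold (0.11 log units) apart, within the scatter of two such steps. So each change carries across the two cores shown, but this rests on just two pairs per change and does not show that it would hold on any other core.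

Going by these compounds, what a chloro group or an amine would do in place of the methyl stays open. So does the effect of a longer chain on the shared core.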